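The compounds below may be only part of what the source reports. "The series", "measured", "known", "first", "only" and "open" are said of these compounds alone.

Of the compounds shown here, two sharing one core have been measured in a functional assay on A2780/DX3 cells (Homo sapiens) for antiproliferative activity, read by MTT assay, with a stated time of 3 days; a higher number here means a weaker inhibitor, a lower number a stronger inhibitor. Compound 2 `CC1=CSC(O)(c2cccc([N+](=O)[O-])c2)c2noc(=O)n21` gives 129000 nM in this assay, and compound 1 `COC1(c2ccc(Cl)cc2)SC=C(C)n2c1noc2=O` gives 113000 nM in this assay; the gap between the two numbers lies within the usual scatter, so neither can be called the stronger inhibitor. Compound 3 `CC1=CSC(O)(c2ccccc2)c2noc(=O)n21` awaits measurement in this assay. It differs from compound 2 in one place: hydrogen in place of nitro on an aromatic carbon. Within the data shown here, no measured step between compounds that differ in a single place is available to lean on, so the estimated step of a 1.0-fold higher number from compound 2 to compound 3 (0.00 log units; within the scatter) is expected to stay within the scatter, with no clear direction. In this assay compound 3 is therefore expected to give about 130000 nM, with a range from 60000 nM to 300000 nM.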

Compound 3, half-maximal inhibitory concentration: > 100000 nM
Compound 3: a limit, no number; the forecaster's own chance of this, stated with the estimate: 15%; the middle value does not contradict the limit.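

In this assay compound 3 gives > 100000 nM, which is a limit and not a number. The step from compound 2 to compound 3 cannot be read. The compounds shown leave open what swapping nitro for hydrogen does to antiproliferative activity.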